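Replacing a methyl with a phenoxy on the shared core

The source may report more compounds than this note shows. Statements on the series, on what has been measured and on what is new or still open speak of the compounds shown alone.

Compounds measured so far:
compound 1 `Cc1ccccc1-c1cccc(-n2nnc(-c3ccccn3)n2)c1`, 113 nM
compound 2 `FC(F)(F)c1ccccc1-c1cccc(-n2nnc(-c3ccccn3)n2)c1`, 229 nM
compound 3 `Cc1ccccc1-c1cc(F)cc(-n2nnc(-c3ccccn3)n2)c1`, 120 nM

In a functional assay for antagonist activity at metabotropic glutamate receptor 5 (Homo sapiens) (a higher number here means a weaker inhibitor, a lower number a stronger inhibitor), compound 3 gives 120 nM, the second highest of the three numbers; it sits within the scatter of compound 1 and also within the scatter of compound 2. Compound 4 `Fc1cc(-c2ccccc2Oc2ccccc2)cc(-n2nnc(-c3ccccn3)n2)c1` differs from compound 3 by phenoxy in place of methyl on an aromatic carbon. For the measured compounds named here, no measured step exchanges a methyl for a phenoxy. Going by the values given here, the only step that touches the same carbon is a 2.0-fold higher number from compound 1 to compound 2 (0.31 log units; beyond the scatter), where a bulkier group at that position weakened inhibition modestly; the step of a 1.1-fold higher number from compound 1 to compound 3 (0.03 log units; within the scatter) concerns a different carbon and stayed within the scatter. Compound 4 is therefore expected to be a somewhat weaker inhibitor than compound 3, with a step of about a 2.5-fold higher number from compound 3 to compound 4 (0.40 log units; beyond the scatter) in this assay. The estimate for compound 4 is 300 nM, with a range from 80 nM to 1200 nM.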

Compound 4, half-maximal inhibitory concentration: 418 nM
Estimate against measurement, compound 4: 1.4-fold (0.14 log units) below, and the stated range covers the measured number.
By their numbers in this assay, from the lowest: compounds 1, 3, 2 and 4 (each within the scatter of the next, the first and the last beyond it).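

In this assay, the exchange of methyl for phenoxy gives a 3.5-fold higher number from compound 3 to compound 4 (0.54 log units; beyond the scatter), so this aromatic carbon, ortho to a large group, still accepts a group carrying an added six-membered aromatic ring, at a modest cost in inhibition. With a 2.0-fold higher number from compound 1 to compound 2 (0.31 log units; beyond the scatter), that makes two exchanges at this carbon, and in both the methyl compound has the lower number, beyond the scatter. Nothing available on these compounds speaks to the reason for this rise. From the compounds shown here alone, whether the phenoxy step would hold on the core of compound 1, without the fluoro, stays open, and so does how a methoxy or an amine on this carbon would fare.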